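Amide replacement in a benzenedisulfonamide series

This account rests on a few compounds, and the source may have more. Where it says the series, first, only, none or still open, it means among the compounds named here.

Of the compounds shown here, three sharing one core have been measured in a functional assay on BXPC-3 cells (Homo sapiens) for inhibition, read by MTT assay, with a stated time of 7 days; a higher number here means a weaker inhibitor, a lower number a stronger inhibitor. Compound 1 `CCOC(=O)[C@@H]1CCCN(S(=N)(=O)c2ccc(S(=O)(=O)N(CC)CC)cc2)C1` gives 13300 nM. Compound 2 `CCN(CC)C(=O)[C@@H]1CCCN(S(=O)(=O)c2ccc(S(=O)(=O)N(CC)CC)cc2)C1` gives 10500 nM, and compound 3 `CCOC(=O)[C@@H]1CCCN(S(=O)(=O)c2ccc(S(=O)(=O)N(CC)CC)c(F)c2)C1` gives 1600 nM. Among these three numbers compound 2 stands second highest: its nearest neighbour is compound 1, whose value lies within the usual scatter of compound 2, so no order between them can be stated. Its furthest neighbour is compound 3, whose value lies beyond the scatter and is clearly lower than that of compound 2. Within the data shown here, none of the measured pairs differs in only one place, so no single step is recorded.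

Compound 4 `CCN(CC)S(=O)(=O)c1ccc(S(=O)(=O)N2CCC[C@@H](C(=O)NC3CN(C(=O)NC(C)(C)C)C3)C2)cc1` arises from compound 2 by one change: (1-((tert-butyl)carbamoyl)azetidin-3-yl)amino in place of diethylamino on a carbonyl carbon. Among the measured compounds shown here, no measured pair shows what such a change does in this assay, and the three numbers at hand give no guidance on it. The expected step from compound 2 to compound 4 is therefore uncertain, and is set at a modest lowering, a 2.1-fold lower number from compound 2 to compound 4 (0.32 log units; beyond the scatter), with a range wide enough to include no change beyond the scatter. Compound 4 is accordingly expected to give about 5000 nM in this assay, with a range from 1000 nM to 25000 nM.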

Compound 4, half-maximal inhibitory concentration: 10100 nM
Compound 4: the middle estimate sits 2.0-fold (0.31 log units) below what was measured; the measured number falls inside the stated range.
By their numbers in this assay, from the lowest: compound 3; then compounds 4, 2 and 1 (each within the scatter of the next).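

In this assay, the first step read at this position, (1-((tert-butyl)carbamoyl)azetidin-3-yl)amino in place of diethylamino on a carbonyl carbon, comes to a 1.0-fold lower number from compound 2 to compound 4 (0.02 log units; within the scatter). The entering group has 12 heavy atoms against 5 and brings a four-membered non-aromatic ring and 2 hydrogen-bond donors, yet this large exchange leaves compound 2 and compound 4 indistinguishable in this read-out, so in this one pair the position accepts the larger group without a shift beyond the scatter. Nothing at hand accounts for this outcome, which remains an observation from a single pair.

The compounds shown leave open whether a quite different group on this carbonyl carbon, such as a carboxylic acid, a simple methylamino or a longer alkyl chain on the amide nitrogen, would move the number beyond the scatter. Among these compounds, they also leave open whether the (1-((tert-butyl)carbamoyl)azetidin-3-yl)amino group would give the same result on the core of compound 3, the one compound here whose number stands clearly apart from that of compound 2.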